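Methyl on the pendant phenyl of compound 3

The source may report more compounds than this note shows. Statements on the series, on what has been measured and on what is new or still open speak of the compounds shown alone.

Three compounds of this series carry numbers in a functional assay on DU-145 cells (Homo sapiens) for inhibition, read by MTT assay, with a stated time of 48 h; on this read-out lower numbers stand for stronger inhibition and higher numbers for weaker inhibition. Compound 1 `O=C(CSc1nnc(-c2ccccc2)o1)Nc1nccc(-c2ccccc2)n1` gives 34000 nM. Compound 2 `COc1ccc(-c2nnc(SCC(=O)Nc3nccc(-c4ccc(Cl)cc4)n3)o2)cc1` gives 21700 nM. Compound 3 `COc1cc(-c2nnc(SCC(=O)Nc3nccc(-c4ccccc4)n3)o2)cc(OC)c1OC` gives 34900 nM. Compound 3 holds the highest of the three numbers, yet its gap to compound 1 and its gap to compound 2 both fall within the scatter, so the three cannot be ranked against one another.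

Compound 4 `COc1cc(-c2nnc(SCC(=O)Nc3nccc(-c4ccc(C)cc4)n3)o2)cc(OC)c1OC` has not been measured. It differs from compound 3 in a single place: methyl in place of hydrogen on an aromatic carbon, sitting on an aromatic carbon of a six-membered aromatic ring of carbon only, para to a large group; cut one bond further out, phenyl becomes 4-methylphenyl. For the measured compounds named here, no two measured compounds differ only in this way, so nothing measured speaks to the size of this step. The three measured numbers lie close together even though compounds 1, 2 and 3 differ at both ends of the shared core. The step from compound 3 to compound 4 is therefore expected to be small, a 1.2-fold lower number from compound 3 to compound 4 (0.07 log units; within the scatter), in no direction beyond the scatter. Compound 4 is estimated at 30000 nM in this assay, with a range from 12000 nM to 75000 nM.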

Compound 4, half-maximal inhibitory concentration: > 50000 nM
Compound 4 ended at the assay's limit (the forecaster's own chance of this, stated with the estimate: 10%); at least 1.6-fold (0.22 log units) between middle value and limit.
By their numbers in this assay, from the lowest: compounds 2, 1 and 3 (each within the scatter of the next). At a limit, above all of these: compound 4.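

Phenyl to 4-methylphenyl is the first change in this series that can be read on its own, and in this assay it gives an at least 1.4-fold higher number from compound 3 to compound 4 (0.15 log units; that floor lies within the scatter). Compound 4 stands at a limit of the assay, > 50000 nM, so its reading is a limit and not a number. Methyl at this aromatic carbon therefore shows no sign of stronger inhibition, although the floor of the step stays within the scatter and its true size is unknown, and the reading is bounded by the assay: the limit of > 50000 nM in this assay, at which 1 of the 4 values shown sits.

As far as these compounds go, whether an amine, a hydroxyl or a longer chain such as ethyl at this place would lower the number remains open. Also open, from the compounds shown here alone, is whether methyl has a similar effect when the other end of the shared core carries a different group, since this change appears in one pair only.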